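A few compounds are considered here, and "the series" means these few. Any claim that something is new, unique, unknown or untested is made for them only; others in the source may bear on it.

Measured compounds:
- compound 1 `CCOC(=O)/C=C(C)/C=C/CC(C)CCCC(C)(C)OC` gives 5.54 in a physicochemical assay for lipophilicity; on this read-out higher numbers stand for higher lipophilicity and lower numbers for lower lipophilicity
- compound 2 `CCOC(=O)/C=C(C)/C=C/CC(C)CCCC(C)(C)OCC` gives 6.08
- compound 3 `CCOC(=O)/C=C(C)/C=C/CC(C)CCC(SCC)C(C)C` gives 6.9

Compound 1 stands lowest of the three. Its nearest neighbour is compound 2, reached by a number 0.54 log units higher from compound 1 to compound 2 (beyond the scatter); the furthest is compound 3, reached by a number 1.36 log units higher from compound 1 to compound 3 (beyond the scatter), and a number 0.82 log units higher from compound 2 to compound 3 (beyond the scatter) links the other two.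

Compound 4 `COC(C)(C)CCCC(C)C/C=C/C(C)=C/C(=O)SC` is not yet measured. It differs from compound 1 in one place: methylsulfanyl in place of ethoxy on a carbonyl carbon. Within the data shown here, no measured step makes this exact change. Two pieces bear on it indirectly: a number 0.54 log units higher from compound 1 to compound 2 (beyond the scatter) shows what one added chain carbon does, here in reverse, since ethoxy carries one carbon more than methylsulfanyl; a number 1.36 log units higher from compound 1 to compound 3 (beyond the scatter) and a number 0.82 log units higher from compound 2 to compound 3 (beyond the scatter) show that exchanging an oxygen-bearing group for a sulfur-bearing one raised the number each time. Set against each other, a modest rise beyond the scatter is expected, a number 0.36 log units higher from compound 1 to compound 4 (beyond the scatter), with the sulfur exchange outweighing the lost carbon. Compound 4 is therefore estimated at 5.9, within 5.4 to 6.4.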

Compound 4, partition coefficient: 6.24
The estimate for compound 4 lay 0.34 log units below the measured number; the range from low to high includes it.
By their numbers in this assay, from the lowest: compound 1; then compounds 2 and 4 (each within the scatter of the next); then compound 3.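

Until compound 4, every compound shown kept ethoxy on the carbonyl carbon, so this is the first view of a change at that position. In this assay, methylsulfanyl in place of ethoxy gives a number 0.70 log units higher from compound 1 to compound 4 (beyond the scatter), so this change at the carbonyl carbon moves the number by more than the usual scatter. The number goes up although the entering group has 2 heavy atoms and the leaving group has 3, and nothing available here explains the rise.

The compounds shown do not separate the swap of oxygen for sulfur from the loss of a carbon, whereas methoxy or ethylsulfanyl on this carbonyl carbon would each change only one of the two. As far as these compounds go, how an amine or a longer chain such as propoxy would read at this position also remains open.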